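Cyano to Methoxy on Compound 2

The compounds below may be only part of what the source reports. "The series", "measured", "known", "first", "only" and "open" are said of these compounds alone.

In a functional assay on U-373MG ATCC cells (Homo sapiens) for inhibition, read by MTT assay, with a stated time of 72 h (on this read-out lower numbers stand for stronger inhibition and higher numbers for weaker inhibition), compound 2 `CC1(C)CC(NC(=S)Nc2cccc(C#N)c2)c2cc(Br)ccc2O1` gives 6000 nM, the lowest of the three numbers, while compound 3 `CC1(C)CC(NC(=S)Nc2cccc(C#N)c2)c2cc(F)ccc2O1` gives 30000 nM and compound 1 `CC1(C)CC(NC(=O)Nc2cccc(Cl)c2)c2cc(Br)ccc2O1` gives 69000 nM. Compound 4 `COc1cccc(NC(=S)NC2CC(C)(C)Oc3ccc(Br)cc32)c1` departs from compound 2 in one place: methoxy in place of cyano on an aromatic carbon. Among the measured compounds shown here, no measured step covers this exchange. The nearest guide is the modest 5.0-fold higher number from compound 2 to compound 3 (0.70 log units; beyond the scatter), which concerns a different group and shows only the size one exchange reached here. Compound 1 differs from compound 2 in more than one place. A modest rise is therefore expected, with the direction uncertain, as an expected 2.0-fold higher number from compound 2 to compound 4 (0.30 log units; within the scatter). For compound 4 the estimated value is 12000 nM, within an expected range of 3500 nM to 40000 nM.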

Compound 4, half-maximal inhibitory concentration: 66000 nM
Beside the measured number, compound 4's estimate is 5.5-fold (0.74 log units) below it, outside the stated range (above it).
By their numbers in this assay, from the lowest: compound 2; then compound 3; then compounds 4 and 1 (each within the scatter of the next).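

The exchange of 3-cyanophenyl for 3-methoxyphenyl in this assay gives an 11-fold higher number from compound 2 to compound 4 (1.04 log units; beyond the scatter) and is the first step shown at this place on the aromatic ring, where it is large, whereas a 5.0-fold higher number from compound 2 to compound 3 (0.70 log units; beyond the scatter) is modest. Cyano and methoxy have the same count of heavy atoms and of hydrogen-bond acceptors, yet the number still moves well beyond the scatter. Nothing at hand offers an explanation for this step.

The compounds shown do not tell how an amine or a carboxylic acid would read at this place. They also leave open whether the exchange would be as large with fluoro in place of bromo.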